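Replacing the Propanoyl Cap with a Chlorobenzoyl Group

This account rests on a few compounds, and the source may have more. Where it says the series, first, only, none or still open, it means among the compounds named here.

compound 1, `CCC(=O)N1CCN(Cc2nc3ccccc3n2Cc2cccc(C)c2)CC1`: 85.1%
compound 2, `O=C(C1CC1)N1CCN(Cc2nc3ccccc3n2Cc2ccccc2C(F)(F)F)CC1`: 56.3%
compound 3, `CC(C)Cn1c(CN2CCN(C(=O)C3CC3)CC2)nc2ccccc21`: 13.1%

Of the compounds shown here, three built on a shared core have been measured in an assay on isolated protein for inhibition of aldehyde dehydrogenase 1A1 (Homo sapiens), read by spectrophotometry, tested at 10 uM; a higher number here means more inhibition at the concentration tested (going by the name of the read-out), a lower number less inhibition. Compound 1 gives 85.1%, the highest of the three numbers. Compound 2 is nearest to it with 56.3%, a gap beyond the scatter, and compound 3 is furthest with 13.1%. Among the compounds with values here, the only step between compounds that differ in a single place is a number 43.2 percentage points lower from compound 2 to compound 3 (beyond the scatter), a change of isopropyl in place of 2-(trifluoromethyl)phenyl on a saturated chain carbon bound to an aromatic nitrogen.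

Compound 4, `Cc1cccc(Cn2c(CN3CCN(C(=O)c4ccc(Cl)cc4)CC3)nc3ccccc32)c1`, differs from compound 1 at a different place: 4-chlorophenyl in place of ethyl on a carbonyl carbon. Within the data shown here, no measured pair varies the group on the carbonyl carbon, so the one large step on record sits elsewhere and does not speak to this change directly. From the compounds shown here alone, because compound 1 already stands at 85.1%, there is little room for a rise in this assay, while a fall of any size remains open. Compound 4 is therefore expected to land near compound 1, with a number 10.1 percentage points lower from compound 1 to compound 4 (beyond the scatter) as the estimated step and wide uncertainty. The estimate for compound 4 is 75%, expected to fall between 40% and 95%.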

Compound 4, a percentage reported as inhibition, at one concentration (the size of the read-out at that concentration, not a potency): 23.2%
The estimate for compound 4 lay 51.8 percentage points above the measured number, and the stated range ends above it.
By their numbers in this assay, from the lowest: compound 3; then compound 4; then compound 2; then compound 1.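

In this assay the group on the carbonyl carbon proves to matter: 4-chlorophenyl in place of ethyl gives a number 61.9 percentage points lower from compound 1 to compound 4 (beyond the scatter) on the shared core, a large step. The earlier compounds shown here offered a single-place comparison only at the saturated chain carbon bound to an aromatic nitrogen, a number 43.2 percentage points lower from compound 2 to compound 3 (beyond the scatter), so the read-out is now seen to respond to changes at two places, with one step on record at each. Nothing at hand bears on why the number fell at the carbonyl carbon.

The step brings in an aromatic ring and a chlorine together, so the compounds shown do not separate the two, and an unsubstituted phenyl or a longer chain such as butyl on the carbonyl carbon would be needed to tell them apart. Also open, from the compounds shown here alone, is how a cyclopropyl on that carbon compares with ethyl when the rest of compound 1 stays fixed, as compound 2 and compound 3 carry cyclopropyl only alongside other groups elsewhere.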